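A Saturated Ring in Place of the Chlorophenyl Group

A few compounds are considered here, and "the series" means these few. Any claim that something is new, unique, unknown or untested is made for them only; others in the source may bear on it.

Compound 1 `CN1CCC[C@@H]1Cn1nc(Cc2ccc(O)cc2)c2ccccc2c1=O` gives 251 nM in an assay for binding affinity to Alpha-1A adrenergic receptor (Homo sapiens); on this read-out higher numbers stand for weaker inhibition and lower numbers for stronger inhibition.
Compound 2 `O=c1c2ccccc2c(Cc2ccc(Cl)cc2)nn1C1CCCN(Cc2ccc(OCCCN3CCCCCC3)cc2)CC1` gives 100 nM in this assay.
Compound 3 `CN1CCC[C@@H]1Cn1nc(Cc2cccc(Cl)c2)c2ccccc2c1=O` gives 398 nM in this assay.

Among these three, compound 3 carries the highest number in this assay. The number of compound 1 lies within the scatter of it, so the two cannot be set apart; compound 2 stands further off, with a lower number beyond the scatter.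

Compound 4 `CN1CCC[C@@H]1Cn1nc(CC2CCCCC2)c2ccccc2c1=O` differs from compound 3 by cyclohexyl in place of 3-chlorophenyl on a saturated chain carbon bound to an aromatic carbon. Going by the values given here, the only measured step that touches the same place is a 1.6-fold higher number from compound 1 to compound 3 (0.20 log units; within the scatter), an exchange of one aromatic substituent for another that left the number within the scatter. Among the compounds with values here, no measured pair exchanges an aromatic ring for a saturated one, so the expectation rests on that single comparison alone, and the size of the present step is less certain than it.

The step from compound 3 to compound 4 in this assay is therefore expected to be small, a 1.3-fold higher number from compound 3 to compound 4 (0.10 log units; within the scatter), with no direction beyond the scatter. Compound 4 is estimated at 500 nM, within a range from 150 nM to 1600 nM.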

Compound 4, inhibition constant: > 1990 nM
Compound 4: no number, only a limit; the forecaster's own chance of this, stated with the estimate: 5%; middle value at least 3.9-fold (0.59 log units) away from the limit.
By their numbers in this assay, from the lowest: compound 2; then compounds 1 and 3 (each within the scatter of the next). At a limit, above all of these: compound 4.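

this assay records compound 4 only as a limit, > 1990 nM. Cyclohexyl in place of 3-chlorophenyl gives an at least 5.0-fold higher number from compound 3 to compound 4 (0.69 log units; beyond the scatter), and cyclohexyl in place of 4-hydroxyphenyl gives an at least 7.9-fold higher number from compound 1 to compound 4 (0.89 log units; beyond the scatter). The earlier compounds shown here showed only an exchange of one aromatic substituent for another on this saturated chain carbon, which stayed within the scatter, whereas the non-aromatic ring of carbon in compound 4 stands clearly apart from both aromatic groups.

Going by these compounds, because compound 4 has only a limit, the full size of both steps stays open. On these data alone, it also remains open whether an unsubstituted phenyl, a pyridine ring or a smaller saturated ring such as cyclopentyl at this place would stay with compounds 1 and 3 or go with compound 4.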